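This account rests on a few compounds, and the source may have more. Where it says the series, first, only, none or still open, it means among the compounds named here.

In an assay on HEK293 cells for positive allosteric modulation of metabotropic glutamate receptor 5 (Homo sapiens), read by FLIPR (a higher number here means that more compound is needed for the effect, a lower number that less compound is needed), two compounds have been measured so far, and neither yielded a number. Compound 1 `Cc1cccc(-c2noc(C3CN(S(=O)(=O)c4cccc(C)c4)C3)n2)c1` gives only a limit of the assay, > 10000 nM. Compound 2 `O=C(C1CCCO1)N1CC(c2nc(-c3cccc(Cl)c3)no2)C1` likewise gives only a limit, > 10000 nM. Both values sit at the limit of > 10000 nM in this assay, at which 2 of the 2 values shown sit, so compound 2 stands at the edge of what the assay reports. Compound 3 `O=C(N1CCCCCC1)N1CC(c2nc(-c3cccc(Cl)c3)no2)C1` differs from compound 2 by azepan-1-yl in place of oxolan-2-yl on a carbonyl carbon. Going by the values given here, no measured step exists to guide the size of this change. The step expected here is a step that the limit leaves unreadable from compound 2 to compound 3, meaning nothing beyond the usual scatter. Compound 3 is therefore estimated at 15000 nM, within a range from 4000 nM to 50000 nM.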

Compound 3, half-maximal effective concentration: 47 nM
The estimate for compound 3 lay 320-fold (2.50 log units) above the measured number; the whole stated range lies above it.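

The position on the carbonyl carbon proves decisive: in this assay, azepan-1-yl in place of oxolan-2-yl brings an at least 210-fold lower number from compound 2 to compound 3 (2.32 log units; beyond the scatter). With both earlier compounds at the limit, nothing had yet shown that this series could give a real number at all. The true step may be larger, since compound 2 gives only a limit: the limit of > 10000 nM in this assay, at which 2 of the 3 values shown sit.

Azepan-1-yl differs from oxolan-2-yl in both ring size and hetero atom, so which difference matters remains open. Whether piperidin-1-yl or an open-chain diethylamino group would keep the low number is also unanswered.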